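The source may hold more compounds than are shown below. What is called first, only, known or untested is meant among the compounds shown, and "the series" means these compounds.

In a toxicity assay on CHO cells (Cricetulus griseus) for cytotoxicity, read by WST assay, with a stated time of 24 h (on this read-out higher numbers stand for weaker inhibition and lower numbers for stronger inhibition), compound 1 (`CC(C)=CCCC(C)=CCNCCCN1CCCC1`) gives > 150000 nM as its reading, which is a limit of the assay and not a number. Compound 2 (`CC(C)=CCCC(C)=CCNCCCN(C)CCCN`) gives > 150000 nM as its reading, again only a limit. Compound 2 therefore has no exact position, and the record so far is the limit of > 150000 nM in this assay, at which 2 of the 2 values shown sit, with nothing finer to compare. For the measured compounds named here, the one measured step is a step that the two limits leave unreadable from compound 1 to compound 2 and it offers no size to carry forward. Compound 3 (`CC(C)=CCCC(C)=CCNCCCN(CCCN)CCCN`) differs from compound 2 by 2-aminoethyl in place of hydrogen on a saturated chain carbon bound to an amine nitrogen and the same difference reads as methyl to 3-aminopropyl. Going by the values given here, with only that unreadable step to go on, no clear shift in either direction is expected in this assay and another limit would be no surprise. The expected size is a number no higher from compound 2 to compound 3 (the limit leaves the size open) on this estimate. For compound 3 the estimated value is 150000 nM with an expected range from 60000 nM to 300000 nM in this reading.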

Compound 3, half-maximal inhibitory concentration: 127000 nM
Compound 3: middle estimate off by 1.2-fold (0.07 log units), on the high side, within the range that was stated.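

Setting 2-aminoethyl in place of hydrogen on a saturated chain carbon bound to an amine nitrogen, which also reads as methyl to 3-aminopropyl, yields the first exact number here: in this assay compound 3 gives 127000 nM. The change is an at least 1.1-fold lower number from compound 2 to compound 3 (0.07 log units; that floor lies within the scatter), so this position tolerates the larger group, but the data show no real shift in the reading. The earlier step cannot be read, and the remaining compounds stay at a limit of the assay rather than a number: the limit of > 150000 nM in this assay, at which 2 of the 3 values shown sit.

Going by these compounds, the reading of compound 2 is only a limit, so its true distance from compound 3 stays open. Also open, on these data alone, is whether 4-aminobutyl or a carboxylic acid in place of 3-aminopropyl would move the number beyond the scatter.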